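From cyclohexylmethyl to benzyl on a shared core

The source may report more compounds than this note shows. Statements on the series, on what has been measured and on what is new or still open speak of the compounds shown alone.

Compound 1 `O=C1Nc2c(ccc(F)c2F)C1(c1ccc(O)cc1)C1CCCCC1`: 13 nM; 18 nM; > 1000 nM (3 entries)
Compound 2 `O=C1Nc2c(ccc(F)c2F)C1(CC1CCCCC1)c1ccc(O)cc1`: 102 nM

In a functional assay on MCF7 cells (Homo sapiens) for cytotoxicity, read by WST assay, with a stated time of 72 h (a lower number here means a stronger inhibitor, a higher number a weaker inhibitor), compound 2 gives 102 nM, a single number. Compound 1 has no single number, and one of its entries in the several entries of compound 1 in this assay, 13 nM; 18 nM; > 1000 nM (3 entries) is a limit, not a measurement.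

Compound 3 `O=C1Nc2c(ccc(F)c2F)C1(Cc1ccccc1)c1ccc(O)cc1` has not been measured. It carries this change: phenyl in place of cyclohexyl on a saturated chain carbon bound to a saturated ring carbon. Among the compounds with values here, no measured pair shows this swap, so the expectation starts from compound 2 at 102 nM. A modest weakening is expected in this assay, the estimated 1.8-fold higher number from compound 2 to compound 3 (0.25 log units; within the scatter). Compound 3 is expected near 180 nM, within an estimated range of 50 nM to 700 nM.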

Compound 3, half-maximal inhibitory concentration: > 1000 nM
Compound 3: a limit, no number; the forecaster's own chance of this, stated with the estimate: 15%; at least 5.5-fold (0.74 log units) between middle value and limit.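

In this assay, phenyl in place of cyclohexyl at this saturated chain carbon gives an at least 9.8-fold higher number from compound 2 to compound 3 (0.99 log units; beyond the scatter), so this position distinguishes two rings of equal heavy-atom count, one aromatic and one not. Going by these compounds, compound 3 gives > 1000 nM, which is a limit of the assay and not a number, so the full size of the step stays unknown. Compound 1 also has one entry at this same limit, so it should be read with care: the limit of > 1000 nM in this assay, at which 1 of the 3 values shown sits.

The compounds shown leave open how an amine or a carboxylic acid at this place would read in this assay. They also leave open whether a longer chain ending in phenyl would behave like the benzyl of compound 3.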